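The compounds below may be only part of what the source reports. "The series", "measured", "known", "first", "only" and "open" are said of these compounds alone.

Measured so far:
Compound 1, `O=C(/C=C/c1coc2cc(O)ccc2c1=O)NCc1ccc(F)cc1`, in a functional assay on L02 cells (Homo sapiens) for inhibition, read by MTT assay, with a stated time of 48 h; on this read-out higher numbers stand for weaker inhibition and lower numbers for stronger inhibition: > 200000 nM, a limit of the assay rather than a number.
Compound 2, `COc1ccc(NC(=O)/C=C/c2coc3cc(OC)ccc3c2=O)cc1`, in this assay: > 200000 nM, likewise a limit and not a number.

Both values shown sit at the same edge, namely (the limit of > 200000 nM in this assay, at which 2 of the 2 values shown sit). For the measured compounds named here, compound 2 therefore stands at the limit, with no measured number of its own, and the one further value shown is a limit as well. Compound 3, `COc1ccc(NC(=O)/C=C/c2coc3cc(O)ccc3c2=O)cc1`, differs from compound 2 in one place: hydrogen in place of methyl on an oxygen on an aromatic ring. Going by the values given here, no step between measured compounds is available, so nothing measured shows how large such a change is in this assay. The step from compound 2 to compound 3 is expected to be a number no higher from compound 2 to compound 3 (the limit leaves the size open), that is, none beyond the usual scatter, because both measured compounds sit at the limit of > 200000 nM in this assay, at which 2 of the 2 values shown sit. Compound 3 is estimated at 200000 nM, with a range from 100000 nM to 400000 nM, and will most likely again be reported only as a limit.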

Compound 3, half-maximal inhibitory concentration: > 200000 nM
Compound 3 gave a limit, no number; the forecaster's own chance of this, stated with the estimate: 85%; the middle value sits exactly at the limit.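

No step can be read between compound 1, compound 2 and compound 3 in this assay, because each value is a limit of the assay and not a number: the limit of > 200000 nM in this assay, at which 3 of the 3 values shown sit. The compounds shown leave open whether methoxy to hydroxy changes inhibition at all, and how far each compound lies from that limit.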